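The source may report more compounds than this note shows. Statements on the series, on what has been measured and on what is new or still open speak of the compounds shown alone.

In an in vitro ADME assay on microsomes from liver (Homo sapiens) for metabolic stability (a higher number here means faster removal of the compound, a lower number slower removal), compound 1 `Cc1cc(Nc2ccc(S(F)(F)(F)(F)F)cc2)n2nc(C3CC3)nc2n1` gives < 5 mL.min-1.g-1, which is a limit of the assay and not a number. Going by the values given here, compound 2 `CSc1nc2nc(C)cc(Nc3ccc(S(F)(F)(F)(F)F)cc3)n2n1` gives 22.4 mL.min-1.g-1, the only actual number so far. Compound 3 `CCC(F)(F)c1nc2nc(C)cc(Nc3ccc(S(F)(F)(F)(F)F)cc3)n2n1` carries 1,1-difluoropropyl in place of methylsulfanyl on an aromatic carbon. One measured step changes a group at this place: an at least 4.4-fold higher number from compound 1 to compound 2 (0.65 log units; beyond the scatter), which rests on (the limit of < 5 mL.min-1.g-1 in this assay, at which 1 of the 2 values shown sits). With methylsulfanyl leaving again, a lower number is expected in this assay, based only on that step. The estimated change is a 2.5-fold lower number from compound 2 to compound 3 (0.40 log units; beyond the scatter). For compound 3 the estimate is 9 mL.min-1.g-1, with an expected range of 4 mL.min-1.g-1 to 22 mL.min-1.g-1.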

Compound 3, intrinsic clearance in microsomes: < 5 mL.min-1.g-1
Compound 3 gave a limit, no number; the forecaster's own chance of this, stated with the estimate: 30%; middle value at least 1.8-fold (0.25 log units) from the limit.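

At this place, on an aromatic carbon between two ring nitrogen atoms, a second group now contrasts with methylsulfanyl in this assay: 1,1-difluoropropyl in its place gives an at least 4.4-fold lower number from compound 2 to compound 3 (0.65 log units; beyond the scatter). Both cyclopropyl and 1,1-difluoropropyl therefore give a lower number than methylsulfanyl. Compound 1 and compound 3 both stop at a limit, not a number, and the step between them cannot be read: the limit of < 5 mL.min-1.g-1 in this assay, at which 2 of the 3 values shown sit.

Open, on these data alone, is where a methoxy group or an amine at this place would fall. Also open, as far as these compounds go, is whether the higher number goes with the sulfur atom of methylsulfanyl.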